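A few compounds are considered here, and "the series" means these few. Any claim that something is new, unique, unknown or untested is made for them only; others in the source may bear on it.

Working notes on the series.

Of the compounds shown here, three of the shared core have been read in a functional assay on HEK293 cells for positive allosteric modulation of metabotropic glutamate receptor 5 (Homo sapiens), read by calcium flux; on this read-out higher numbers stand for larger maximal responses and lower numbers for smaller maximal responses. Compound 1 `O=C1c2cc(COc3ccccc3)nn2CCN1c1ccc(F)cc1` gives 79%. Compound 2 `O=C1c2cc(COc3ccccc3)nn2CCN1c1ccncc1` gives 72%; the step of a number 7 percentage points lower from compound 1 to compound 2 (within the scatter) stays within the scatter. Compound 3 `O=C1c2cc(COc3ccccc3F)nn2CCN1c1ccc(F)cc1` gives 66%; the step of a number 13 percentage points lower from compound 1 to compound 3 (beyond the scatter) is modest but beyond the scatter. Compound 3 thus stands beyond the scatter below compound 1, while compound 2 lies within the scatter of it, so no order between compound 3 and compound 2 can be read from the numbers.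

Compound 4 `O=C1c2cc(COc3cccc(F)c3)nn2CCN1c1ccc(F)cc1` is not yet measured. It differs from compound 3 in this way: 3-fluorophenyl in place of 2-fluorophenyl on an oxygen on a saturated carbon. Going by the values given here, no measured step moves a fluoro between two positions of the same ring; the only step touching this ring is the hydrogen-to-fluoro change that gave a number 13 percentage points lower from compound 1 to compound 3 (beyond the scatter), and it does not say whether the position of the fluoro matters. In the absence of a bearing step, no change beyond the scatter is expected in this assay, and the step of a number 2 percentage points higher from compound 3 to compound 4 (within the scatter) is an estimate around the value of compound 3. Compound 4 is expected to give 68%, in a range from 52% to 84%.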

Compound 4, largest response reached (Emax), in percent of the reference or control that the assay uses: 70%
Compound 4: the middle estimate sits 2 percentage points below what was measured; the measured number falls inside the stated range.
By their numbers in this assay, from the lowest: compounds 3, 4, 2 and 1 (each within the scatter of the next, the first and the last beyond it).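

Moving the fluoro on the group carried by the oxygen, 3-fluorophenyl in place of 2-fluorophenyl, gives a number 4 percentage points higher from compound 3 to compound 4 (within the scatter) in this assay, so this pair does not show that the position of the fluoro on this ring matters. Going by these compounds alone, the hydrogen-to-fluoro change now has two readings on the same ring, a number 13 percentage points lower from compound 1 to compound 3 (beyond the scatter) and a number 9 percentage points lower from compound 1 to compound 4 (within the scatter), so a step beyond the scatter is seen only with 2-fluorophenyl and does not hold for every fluoro on this ring, although compounds 3 and 4 themselves cannot be told apart. Nothing at hand offers an explanation for these readings.

Still open, going by these compounds, is whether a chloro, a methoxy or a nitrile in place of the fluoro on this ring would stay within the scatter of compound 1, and whether a longer chain in place of the saturated carbon on the oxygen would keep the response. Also open, on these data alone, is whether 3-fluorophenyl combined with pyridin-4-yl on the amide-type nitrogen would stay close to the reading of compound 2 at 72%.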